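Swapping the nitrile for a methylsulfonyl on the benzyl arm

The source may report more compounds than this note shows. Statements on the series, on what has been measured and on what is new or still open speak of the compounds shown alone.

Compound 1 `CCOC(=O)c1cnc(N2CCN(Cc3cccc(C#N)c3)CC2)nc1Oc1c(C)cc(-c2ccc(C#N)cc2)cc1C` was tested in an ADME assay on MT4 cells (Homo sapiens) for cytotoxicity, read by MTT assay, with a stated time of 4 days; a higher number here means that more compound is tolerated, a lower number that less compound is tolerated. In this assay compound 1 gives > 125000 nM, which is a limit of the assay and not a number, as the limit of > 125000 nM in this assay, at which 1 of the 2 values shown sits, shows. Compound 2 `CCOC(=O)c1cnc(N2CCN(Cc3cccc(C(N)=O)c3)CC2)nc1Oc1c(C)cc(-c2ccc(C#N)cc2)cc1C` differs from compound 1 in one place; in this assay compound 2 gives 14800 nM, and the step is an at least 8.4-fold lower number from compound 1 to compound 2 (0.92 log units; beyond the scatter). Compound 3 `CCOC(=O)c1cnc(N2CCN(Cc3ccc(S(C)(=O)=O)cc3)CC2)nc1Oc1c(C)cc(-c2ccc(C#N)cc2)cc1C` has not yet been measured. It differs from compound 1 as follows: 4-(methylsulfonyl)phenyl in place of 3-cyanophenyl on a saturated chain carbon bound to an amine nitrogen in a ring. Within the data shown here, no measured step covers exactly this change; the one measured step, from compound 1 to compound 2, also removes the nitrile and lowers the tolerated amount. A step in the same direction is therefore expected, with the expected size being an at least 2.5-fold lower number from compound 1 to compound 3 (0.39 log units; beyond the scatter). For compound 3 the expected value is 50000 nM, within a range from 12000 nM to 125000 nM.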

Compound 3, half-maximal cytotoxic concentration: > 125000 nM
Compound 3 was reported as a limit; the forecaster's own chance of this, stated with the estimate: 40%; at least 2.5-fold (0.39 log units) between middle value and limit.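

In this assay compound 3 gives > 125000 nM, which is a limit of the assay and not a number. Losing the nitrile from the benzyl arm therefore does not by itself lower the tolerated amount, as 4-(methylsulfonyl)phenyl in place of 3-carbamoylphenyl gives an at least 8.4-fold higher number from compound 2 to compound 3 (0.92 log units; beyond the scatter). The step from compound 1 to compound 3 cannot be read, because both compounds stand at the same limit: the limit of > 125000 nM in this assay, at which 2 of the 3 values shown sit.

From the compounds shown here alone, compound 2 and compound 3 differ in both the group and its numbered place on the phenyl ring, so it stays open whether the lower number of compound 2 goes with the carbamoyl group or with the 3-position. Going by these compounds, a 4-carbamoylphenyl would speak to that question, and how a carboxylic acid or an amine on the same arm would behave in this assay also remains open.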